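This account rests on a few compounds, and the source may have more. Where it says the series, first, only, none or still open, it means among the compounds named here.

Compound 1, `CCC(=O)Nc1ccc(-c2nc3cc(C(F)(F)F)ccc3[nH]2)cc1`, is tested in an ADME assay on MT4 cells (Homo sapiens) for cytotoxicity, read by MTT assay, with a stated time of 96 h (a higher number here means that more compound is tolerated, a lower number that less compound is tolerated), and there compound 1 gives >= 100000 nM. That value of compound 1 is a limit of the assay and not a number, namely (the limit of >= 100000 nM in this assay, at which 1 of the 3 values shown sits). Compound 3, `CCC(=O)Nc1ccc(-c2nc3ccccc3[nH]2)cc1`, gives 35000 nM in this assay. The change is hydrogen in place of trifluoromethyl on an aromatic carbon, and the step is an at least 2.8-fold lower number from compound 1 to compound 3 (0.45 log units; beyond the scatter). Compound 2, `O=[N+]([O-])c1ccc(-c2nc3cc(C(F)(F)F)ccc3[nH]2)c([N+](=O)[O-])c1`, gives 9000 nM in this assay; how the core of compound 2 differs from that of compound 1 is not broken down here. Compound 4, `O=[N+]([O-])c1ccc(-c2nc3ccccc3[nH]2)c([N+](=O)[O-])c1`, is not yet measured in this assay; it differs from compound 2 by hydrogen in place of trifluoromethyl on an aromatic carbon, the same change as from compound 1 to compound 3. For compound 4 a step of a 2.3-fold lower number from compound 2 to compound 4 (0.35 log units; beyond the scatter) is expected, and this rests on an at least 2.8-fold lower number from compound 1 to compound 3 (0.45 log units; beyond the scatter). Compound 4 is thus estimated at 4000 nM, between 1500 nM and 12000 nM.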

Compound 4, half-maximal cytotoxic concentration: 7000 nM
Estimate against measurement, compound 4: 1.8-fold (0.24 log units) below; low and high end bracket the measured number.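

In this assay, hydrogen in place of trifluoromethyl gives a 1.3-fold lower number from compound 2 to compound 4 (0.11 log units; within the scatter), so on this core the two compounds cannot be told apart. This does not show that the change behaves differently on the two cores, nor that it carries over from one to the other with the same size: the same change on two cores in this assay, an at least 2.8-fold lower number (0.45 log units; beyond the scatter) from compound 1 to compound 3 and a 1.3-fold lower number (0.11 log units; within the scatter) from compound 2 to compound 4; the limit leaves it open whether they differ The value of compound 1, >= 100000 nM, is a limit of the assay and not a number.

The compounds shown cover only two cores and only trifluoromethyl or hydrogen at this place, which leaves open what a chlorine, a methoxy group or a nitrile would give there. Also open, from the compounds shown here alone, is how the same change reads on a third core, for instance one carrying an amine in place of the nitro groups.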